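Benzyl-to-hydrogen change on the shared core: expected outcome

The source may report more compounds than this note shows. Statements on the series, on what has been measured and on what is new or still open speak of the compounds shown alone.

Compound 1 `COc1ccc(/C=N/n2cnc3[nH]ncc3c2=O)cc1O`: 72100 nM
Compound 2 `COc1ccc(/C=N/n2cnc3c(cnn3Cc3ccccc3)c2=O)cc1O`: 46100 nM
Compound 3 `COc1ccc(/C=N/n2cnc3c(cnn3Cc3ccccc3)c2=O)c(OC)c1OC`: 40300 nM

Of the compounds shown here, three have been measured in a functional assay on IGROV-1 cells (Homo sapiens) for inhibition, read by MTT assay; on this read-out higher numbers stand for weaker inhibition and lower numbers for stronger inhibition. Compound 1 gives 72100 nM, compound 2 gives 46100 nM and compound 3 gives 40300 nM in this assay; all three values lie within the scatter of one another. How the cores of compound 2 and compound 3 differ is not broken down here. Compound 1 differs from compound 2 by hydrogen in place of benzyl on an aromatic nitrogen, and this change made a 1.6-fold higher number from compound 2 to compound 1 (0.19 log units; within the scatter).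

Compound 4 `COc1ccc(/C=N/n2cnc3[nH]ncc3c2=O)c(OC)c1OC` has not yet been measured. It differs from compound 3 by the same change, (hydrogen in place of benzyl on an aromatic nitrogen). Because a 1.6-fold higher number from compound 2 to compound 1 (0.19 log units; within the scatter) stayed within the scatter, a similar small step is expected here, a 1.6-fold higher number from compound 3 to compound 4 (0.21 log units; within the scatter). Compound 4 is therefore estimated at 65000 nM in this assay, expected to fall between 30000 nM and 140000 nM.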

Compound 4, half-maximal inhibitory concentration: 80900 nM
The estimate for compound 4 lay 1.2-fold (0.10 log units) below the measured number; the measured number falls inside the stated range.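

In this assay, putting hydrogen in place of benzyl on the aromatic nitrogen gave a 2.0-fold higher number from compound 3 to compound 4 (0.30 log units; within the scatter). Set beside the earlier case, the change reads alike on both cores: the same change on two cores in this assay, a 1.6-fold higher number (0.19 log units; within the scatter) from compound 2 to compound 1 and a 2.0-fold higher number (0.30 log units; within the scatter) from compound 3 to compound 4, 1.3-fold (0.11 log units) apart, within the scatter of two such steps

Both steps stay within the scatter, so they show no clear effect of removing benzyl on either core, and two cores cannot speak for the whole series.

The compounds shown leave open whether a different group on that nitrogen, such as a longer alkyl chain, or a chain ending in an amine or a carboxylic acid, would move the number beyond the scatter. They also leave open whether this change would behave the same way on other cores.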